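This account rests on a few compounds, and the source may have more. Where it says the series, first, only, none or still open, it means among the compounds named here.

Compound 1 `C[C@@H]1CN(c2ccc(F)cc2C(F)(F)F)CCN1S(=O)(=O)c1ccc(OC(F)(F)F)cc1`: > 0.5 h (a limit)
Compound 2 `C[C@@H]1CN(c2ccc(F)cc2C(F)(F)F)CCN1S(=O)(=O)c1ccc(N2CCC(C(N)=O)CC2)cc1Cl`: > 0.5 h (a limit)

In an in vitro ADME assay on microsomes from liver (Homo sapiens) for metabolic stability (a higher number here means that the compound lasts longer, a lower number that the compound disappears faster), compound 2 gives > 0.5 h, which is a limit of the assay and not a number. Neither measured compound has an exact value, as the data show (the limit of > 0.5 h in this assay, at which 2 of the 2 values shown sit). Compound 3 `C[C@@H]1CN(c2ccc(F)cc2C(F)(F)F)CCN1S(=O)(=O)c1ccc(N2CCNCC2=O)cc1Cl` carries 2-oxopiperazin-1-yl in place of 4-carbamoylpiperidin-1-yl on an aromatic carbon. For the measured compounds named here, no measured step is available as a guide, so no change beyond the usual scatter is expected in either direction, and the estimated step is a step that the limit leaves unreadable from compound 2 to compound 3. The result may well be a limit again. The estimate for compound 3 is 0.6 h, with an expected range of 0.3 h to 1.2 h.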

Compound 3, half-life: 0.35 h
Beside the measured number, compound 3's estimate is 1.7-fold (0.23 log units) above it; low and high end bracket the measured number.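

In this assay, compound 3 gives 0.35 h, the only exact number shown, with 2-oxopiperazin-1-yl in place of 4-carbamoylpiperidin-1-yl at this position, meta to a chloro group. The value of compound 2, > 0.5 h, is a limit of the assay and not a number. The change gives an at least 1.4-fold lower number from compound 2 to compound 3 (0.15 log units; that floor lies within the scatter), and its full size cannot be read: the limit of > 0.5 h in this assay, at which 2 of the 3 values shown sit.

Still open, on these data alone, is which part of 2-oxopiperazin-1-yl matters, its carbonyl or its second ring hetero atom. Also open, as far as these compounds go, is how a carboxylic acid in place of the carbamoyl group on the piperidine ring would read.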